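Cyclohexyl in place of 3-fluorocyclobutyl: half-life notes

The source may hold more compounds than are shown below. What is called first, only, known or untested is meant among the compounds shown, and "the series" means these compounds.

In an ADME assay on microsomes from liver (Homo sapiens) for metabolic stability, read by LC-MS, using NADPH, with a stated time of 10 min, tested at 10 uM (a lower number here means that the compound disappears faster, a higher number that the compound lasts longer), compound 3 (`Nc1ncnc2c1c(Oc1cc(C(F)(F)F)ccn1)nn2[C@H]1C[C@H](F)C1`) gives 2.03 h, and compound 1 (`Nc1ncnc2c1c(Oc1cc(C(F)(F)F)ccn1)nn2CC1CC1`) gives 1.87 h, with a 1.1-fold higher number from compound 1 to compound 3 (0.04 log units; within the scatter). Compound 2 (`CO[C@H]1CC[C@@H](n2nc(Oc3cc(C(F)(F)F)ccn3)c3c(N)ncnc32)CC1`) gives 0.317 h, so compound 3 sits well clear of it, with a 6.4-fold higher number from compound 2 to compound 3 (0.81 log units; beyond the scatter).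

Compound 4 (`Nc1ncnc2c1c(Oc1cc(C(F)(F)F)ccn1)nn2C1CCCCC1`) has cyclohexyl in place of 3-fluorocyclobutyl on an aromatic nitrogen.

Going by the values given here, the nearest precedent is compound 2, the only measured member with a six-membered ring there, reached by a 5.9-fold lower number from compound 1 to compound 2 (0.77 log units; beyond the scatter). Among the compounds with values here, no measured pair separates its methoxy group from that ring, so only part of this drop is expected to carry over.

The expected change is a 3.4-fold lower number from compound 3 to compound 4 (0.53 log units; beyond the scatter). Compound 4 is estimated at 0.6 h, with an expected range of 0.25 h to 1.4 h.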

Compound 4, half-life: 0.55 h
Estimate against measurement, compound 4: 1.1-fold (0.04 log units) above, and the stated range covers the measured number.
By their numbers in this assay, from the lowest: compounds 2 and 4 (each within the scatter of the next); then compounds 1 and 3 (each within the scatter of the next).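

In this assay, plain cyclohexyl on the aromatic nitrogen is enough for the loss, seen against 3-fluorocyclobutyl (a 3.7-fold lower number from compound 3 to compound 4 (0.57 log units; beyond the scatter)) and against cyclopropylmethyl (a 3.4-fold lower number from compound 1 to compound 4 (0.53 log units; beyond the scatter)). Hydrogen in place of methoxy on the ring stays within the scatter (a 1.7-fold higher number from compound 2 to compound 4 (0.24 log units; within the scatter)), so the methoxy group is not required for the short half-life of compound 2. No measurement at hand bears on the reason for this.

On these data alone, whether the fluorine matters remains open, pending plain cyclobutyl at this position. Where cyclopentyl would fall, and whether an amine on the cyclohexyl ring would change the half-life, also remain open.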